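The source may hold more compounds than are shown below. What is called first, only, known or untested is meant among the compounds shown, and "the series" means these compounds.

Compound 2 `COc1cccc(NC(=O)Nc2cc(C(C)(C)C)nn2-c2ccccc2)c1` and compound 1 `CCOc1ccc(NC(=O)Nc2cc(C(C)(C)C)nn2-c2ccccc2)cc1` share one core and differ only in the aryl group on the urea-type nitrogen. Within the data shown here, in an assay on isolated protein for inhibition of serine/threonine-protein kinase 10 (Homo sapiens), read by thermal shift assay, tested at 10 uM (a higher number here means that the compound stabilises the target more against heat, a lower number that the compound stabilises the target less), compound 1 gives 0.8 degrees C, and in this assay compound 2 gives 3.7 degrees C. The change a number 2.9 degrees C higher from compound 1 to compound 2 (beyond the scatter) is the only step measured so far, and it puts compound 2 at the top of the two numbers known, with compound 1 as its nearest neighbour.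

Compound 3 `Cc1ccc(NC(=O)Nc2cc(C(C)(C)C)nn2-c2ccccc2)cc1` is the next member: 4-methylphenyl in place of 3-methoxyphenyl on an amide-type nitrogen. Among the measured compounds shown here, the single measured step bears on it, since it too swaps the aryl on that nitrogen; it went from a 4-ethoxyphenyl to a 3-methoxyphenyl and was modest in size. Compound 3 returns to a 4-substituted phenyl, as in compound 1, so a step back in the other direction is expected in this assay, estimated at a number 1.9 degrees C lower from compound 2 to compound 3 (beyond the scatter). Compound 3 is therefore expected to give about 1.8 degrees C, within 0.3 degrees C to 3.5 degrees C.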

Compound 3, shift of the target's melting temperature: 4.7 degrees C
Estimate against measurement, compound 3: 2.9 degrees C below; measured number outside the range, above it.
By their numbers in this assay, from the lowest: compound 1; then compounds 2 and 3 (each within the scatter of the next).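

In this assay, putting 4-methylphenyl in place of 3-methoxyphenyl on the amide-type nitrogen gives a number 1.0 degrees C higher from compound 2 to compound 3 (within the scatter), so these two aryl groups cannot be told apart here. Methyl in place of ethoxy on an aromatic carbon gives a number 3.9 degrees C higher from compound 1 to compound 3 (beyond the scatter), which shows that a group at the 4 place of the phenyl does not by itself bring a low number; among these three compounds, the low number stands with 4-ethoxyphenyl alone. Nothing at hand explains these differences. On these data alone, it remains open whether 4-methoxyphenyl would fall with compound 1 or with compound 3, which would separate the length of the chain from the oxygen it carries. Also open, as far as these compounds go, is what an amine or a carboxylic acid on this phenyl would give.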